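A few compounds are considered here, and "the series" means these few. Any claim that something is new, unique, unknown or untested is made for them only; others in the source may bear on it.

Compound 1 `CCCCCCCOC(=O)CCC(=O)N1CCN(CCCOc2cc3c(Nc4ccc(F)c(Cl)c4)ncnc3cc2OC)CC1`: 59.1%
Compound 2 `CCCCCCCCOC(=O)CCC(=O)N1CCN(CCCOc2cc3c(Nc4ccc(F)c(Cl)c4)ncnc3cc2OC)CC1`: 48.7%
Compound 3 `CCCCCCCCCCCCCOC(=O)CCC(=O)N1CCN(CCCOc2cc3c(Nc4ccc(F)c(Cl)c4)ncnc3cc2OC)CC1`: 71.1%

These three compounds were tested in a functional assay on A549 cells (Homo sapiens) for cytotoxicity, read by MTT assay, with a stated time of 24 h, tested at 40 uM; on this read-out higher numbers stand for a weaker effect at the one concentration tested and lower numbers for a stronger effect. Compound 4 `CCCCCCCCCCCCCCOC(=O)CCC(=O)N1CCN(CCCOc2cc3c(Nc4ccc(F)c(Cl)c4)ncnc3cc2OC)CC1` has not yet been measured. From compound 1 to compound 2 the change is methyl in place of hydrogen on a saturated chain carbon, seven bonds along the chain from an oxygen next to a carbonyl group, and it gave a number 10.4 percentage points lower from compound 1 to compound 2 (beyond the scatter). The core of compound 3 differs from that of compound 1 by hexyl in place of hydrogen on a saturated chain carbon, seven bonds along the chain from an oxygen next to a carbonyl group. From compound 3 to compound 4 the change is methyl in place of hydrogen on a saturated chain carbon, ten or more bonds along the chain from an oxygen next to a carbonyl group; this is the same kind of change as from compound 1 to compound 2, but not the same, since the place along the chain differs, as the two descriptions of the changes show. The three measured numbers do not move in one direction with chain length, as compound 3 stands higher than both compound 1 and compound 2 despite its longer chain. An expectation for compound 4 therefore rests on compound 3 and on the modest earlier step of a number 10.4 percentage points lower from compound 1 to compound 2 (beyond the scatter), and the expected step is a number 5.1 percentage points lower from compound 3 to compound 4 (within the scatter). Compound 4 is estimated at 66%, with a likely range from 50% to 82%.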

Compound 4, a percentage reported as activity, at one concentration (the size of the read-out at that concentration, not a potency): 88.6%
Beside the measured number, compound 4's estimate is 22.6 percentage points below it; the measured number lies above the stated range.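

In this assay, adding a methyl at the end of the chain does not carry a fixed effect from one core to another, and even its direction differs: the same change on two cores in this assay, a number 10.4 percentage points lower (beyond the scatter) from compound 1 to compound 2 and a number 17.5 percentage points higher (beyond the scatter) from compound 3 to compound 4, 27.9 percentage points apart, beyond the scatter of two such steps. Longer additions to the chain all raise the number, but their size also depends on the starting compound: the same change on two cores in this assay, a number 12 percentage points higher (beyond the scatter) from compound 1 to compound 3 and a number 39.9 percentage points higher (beyond the scatter) from compound 2 to compound 4, 27.9 percentage points apart, beyond the scatter of two such steps. All three new steps point towards a weaker effect, a number 17.5 percentage points higher from compound 3 to compound 4 (beyond the scatter), a number 39.9 percentage points higher from compound 2 to compound 4 (beyond the scatter) and a number 29.5 percentage points higher from compound 1 to compound 4 (beyond the scatter), yet compound 2 goes against any steady rise with chain length, so these four compounds show no rule that could be carried to other chain lengths and do not explain the reversal.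

Going by these compounds, the chain lengths between those of compound 2 and compound 3 remain open, so the point at which the number turns upward cannot be placed. Also open, on these data alone, is how a branched chain, a chain ending in an amine or a carboxylic acid, or an amide in place of the ester would behave.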